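This account rests on a few compounds, and the source may have more. Where it says the series, first, only, none or still open, it means among the compounds named here.

Of the compounds shown here, three sharing one core have been measured in an ADME assay on HEK293 cells (Homo sapiens) for cytotoxicity; on this read-out lower numbers stand for stronger inhibition and higher numbers for weaker inhibition. There, compound 1 (`CCCCCCCCCCCCCCNC(=O)[C@H](CO)/N=C/c1ccccc1O`) gives 80800 nM and compound 2 (`CCCCCCCCCCCCCCNC(=O)[C@H](CO)/N=C/c1cccc([N+](=O)[O-])c1`) gives 82700 nM, while compound 3 (`CCCCCCCCCCCCCCNC(=O)[C@H](CO)/N=C/c1ccc(O)cc1`) gives 71700 nM and so stands within the scatter of both. Compound 4 (`CCCCCCCCCCCCCCNC(=O)[C@H](CO)/N=C/c1ccc(C)cc1`) has methyl in place of hydroxy on an aromatic carbon. The nearest evidence comes from swaps of the same aromatic group: a 1.1-fold lower number from compound 1 to compound 3 (0.05 log units; within the scatter) and a 1.2-fold lower number from compound 2 to compound 3 (0.06 log units; within the scatter), along with a 1.0-fold higher number from compound 1 to compound 2 (0.01 log units; within the scatter), all within the scatter. None involves methyl, so the basis is indirect, but no step beyond the scatter is expected in this assay. The expected change is a 1.0-fold higher number from compound 3 to compound 4 (0.02 log units; within the scatter) only. Compound 4 is estimated at 75000 nM (range 45000 nM to 120000 nM).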

Compound 4, half-maximal inhibitory concentration: 47300 nM
The estimate for compound 4 lay 1.6-fold (0.20 log units) above the measured number, within the range that was stated.
By their numbers in this assay, from the lowest: compounds 4, 3, 1 and 2 (each within the scatter of the next).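

Swapping hydroxy for methyl on this aromatic carbon removes a hydrogen-bond donor and acceptor, yet in this assay the result is a 1.5-fold lower number from compound 3 to compound 4 (0.18 log units; within the scatter) and so does not exceed the usual scatter. The wider swaps give a 1.7-fold lower number from compound 2 to compound 4 (0.24 log units; within the scatter) and a 1.7-fold lower number from compound 1 to compound 4 (0.23 log units; within the scatter) and also stay within it, so none of the four aromatic groups can be told apart in this assay. No evidence bears on why this is so. Going by these compounds, whether an amine or a carboxylic acid at this place would give a step beyond the scatter remains open, as does the effect of changes elsewhere on the shared core.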